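The source may report more compounds than this note shows. Statements on the series, on what has been measured and on what is new or still open speak of the compounds shown alone.

The compounds share one core. Compound 1 `CN(C(=O)NC(=O)c1ccc(Cl)cc1Cl)c1nc(C(F)(F)F)c(C(=O)N/N=C/c2cccc(C(F)(F)F)c2)s1` and compound 3 `CN(C(=O)NC(=O)c1ccccc1F)c1nc(C(F)(F)F)c(C(=O)N/N=C/c2cc(C(F)(F)F)cc(C(F)(F)F)c2)s1` carry a larger attachment on it, while compound 2 `CNc1nc(C)c(C(=O)N/N=C/c2cccc(C(F)(F)F)c2)s1` and compound 4 `CNc1nc(C)c(C(=O)N/N=C/c2cc(C(F)(F)F)cc(C(F)(F)F)c2)s1` carry a smaller one. In a functional assay on HeLa cells (Homo sapiens) for inhibition, read by MTT assay, with a stated time of 72 h (on this read-out lower numbers stand for stronger inhibition and higher numbers for weaker inhibition), compound 1 gives 9.6 ug/mL and compound 3 gives 4.98 ug/mL. Compound 2 gives > 100 ug/mL, which is a limit of the assay and not a number, so compound 2 sits at the limit of > 100 ug/mL in this assay, at which 1 of the 3 values shown sits. Compound 4 differs from compound 2 by trifluoromethyl in place of hydrogen on an aromatic carbon. Among the measured compounds shown here, no measured pair differs only in this way, so the change is expected to be small, without a clear direction beyond the scatter, and a limit is again possible. Compound 4 is therefore estimated at 80 ug/mL, within 25 ug/mL to 250 ug/mL, an expected step of an at least 1.2-fold lower number from compound 2 to compound 4 (0.09 log units; that floor lies within the scatter) in this assay.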

Compound 4, half-maximal inhibitory concentration: > 100 ug/mL
Compound 4 was reported as a limit; the forecaster's own chance of this, stated with the estimate: 60%; at least 1.2-fold (0.09 log units) between middle value and limit.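

Compound 2 and compound 4 are both reported only as limits, so no step between them can be read: the limit of > 100 ug/mL in this assay, at which 2 of the 4 values shown sit.

The compounds shown leave open whether trifluoromethyl in place of hydrogen on an aromatic carbon changes inhibition at all when the smaller attachment is present.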